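Trifluoromethyl in place of nitro on the benzamide

This account rests on a few compounds, and the source may have more. Where it says the series, first, only, none or still open, it means among the compounds named here.

Measured so far:
compound 1, `CCCCCCCCCCCCn1nnc(C(NC(=O)c2ccc(Cl)cc2)c2ccccc2)n1`: 440 nM
compound 2, `CCCCCCCCCCCCn1nnc(C(NC(=O)c2ccc(C)cc2)c2ccccc2)n1`: 510 nM
compound 3, `CCCCCCCCCCCCn1nnc(C(NC(=O)c2ccccc2[N+](=O)[O-])c2ccccc2)n1`: 240 nM

Going by the values given here, in an assay on microsomes from liver for inhibition of sterol O-acyltransferase 1 (Rattus norvegicus) (on this read-out higher numbers stand for weaker inhibition and lower numbers for stronger inhibition), compound 3 has the lowest number of the three; its gap to compound 1 lies within the scatter, so only the step of a 2.1-fold lower number from compound 2 to compound 3 (0.33 log units; beyond the scatter) separates it from another compound. Compound 4, `CCCCCCCCCCCCn1nnc(C(NC(=O)c2ccc(C(F)(F)F)cc2)c2ccccc2)n1`, differs from compound 3 by 4-(trifluoromethyl)phenyl in place of 2-nitrophenyl on a carbonyl carbon. Among the compounds with values here, two measured steps bear on this: a 1.8-fold lower number from compound 1 to compound 3 (0.26 log units; within the scatter) and a 2.1-fold lower number from compound 2 to compound 3 (0.33 log units; beyond the scatter), both replacing a phenyl carrying a single group with 2-nitrophenyl. Running that change backwards, compound 4 is expected to land near compounds 1 and 2, a small step up in this assay from compound 3, a 2.0-fold higher number from compound 3 to compound 4 (0.30 log units; within the scatter), at the edge of the scatter. The estimate for compound 4 is 480 nM, ranging from 240 nM to 960 nM.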

Compound 4, half-maximal inhibitory concentration: 850 nM
Beside the measured number, compound 4's estimate is 1.8-fold (0.25 log units) below it; the range from low to high includes it.
By their numbers in this assay, from the lowest: compounds 3, 1, 2 and 4 (each within the scatter of the next, the first and the last beyond it).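

In this assay, the step of a 3.5-fold higher number from compound 3 to compound 4 (0.55 log units; beyond the scatter) is the widest yet at this carbonyl carbon and separates 2-nitrophenyl from 4-(trifluoromethyl)phenyl beyond the scatter. On the aromatic carbon, trifluoromethyl does not separate from methyl or chloro: a 1.7-fold higher number from compound 2 to compound 4 (0.22 log units; within the scatter) and a 1.9-fold higher number from compound 1 to compound 4 (0.29 log units; within the scatter) both stay within the scatter. Nothing measured here explains these differences.

Going by these compounds, whether the gap between compound 3 and compound 4 goes with the nitro group itself or with where it sits on the ring remains open. So does how an amine or a carboxylic acid on this ring would read.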